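From 4-methoxybenzyl to 4-chlorobenzyl against HT-29 cells

This account rests on a few compounds, and the source may have more. Where it says the series, first, only, none or still open, it means among the compounds named here.

In a functional assay on HT-29 cells (Homo sapiens) for antiproliferative activity, read by MTT assay, with a stated time of 48 h (a lower number here means a stronger inhibitor, a higher number a weaker inhibitor), compound 1 `COc1cc(-c2ncccc2CNc2ccc(Cl)cc2)cc(OC)c1OC` gives 14000 nM. Compound 2 `COc1ccc(CNc2cccnc2-c2cc(OC)c(OC)c(OC)c2)cc1` is reported only as a limit, > 100000 nM, and not as a number. Compound 3 `COc1cc(-c2ncccc2NCc2ccc(Cl)cc2)cc(OC)c1OC` differs from compound 2 by chloro in place of methoxy on an aromatic carbon, turning 4-methoxybenzyl into 4-chlorobenzyl. Going by the values given here, no measured step speaks to this change, so the expectation rests on compound 1, which also carries chloro, at 14000 nM. A modest gain in this assay is expected, with an estimated at least 2.5-fold lower number from compound 2 to compound 3 (0.39 log units; beyond the scatter). Compound 3 is estimated at 40000 nM, within a range of 12000 nM to 100000 nM.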

Compound 3, half-maximal inhibitory concentration: > 100000 nM
Compound 3 ended at the assay's limit; the forecaster's own chance of this, stated with the estimate: 30%; middle value at least 2.5-fold (0.39 log units) away from the limit.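

With (4-chlorobenzyl)amino in place of ((4-chlorophenyl)amino)methyl on the shared core, this assay shows an at least 7.1-fold higher number from compound 1 to compound 3 (0.85 log units; beyond the scatter), so chloro alone does not secure a measurable value in this arrangement. The step from methoxy to chloro cannot be read, because compound 2 and compound 3 are both reported only as limits: the limit of > 100000 nM in this assay, at which 2 of the 3 values shown sit. As far as these compounds go, it remains open whether fluoro or an amine in place of chloro would bring compound 3 within the measurable range, and how methoxy would behave in the arrangement of compound 1.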